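From diaryl urea to benzamide: an untested change

This account rests on a few compounds, and the source may have more. Where it says the series, first, only, none or still open, it means among the compounds named here.

Measured so far:
compound 1 `COc1cc(-c2nn(-c3cccc(NC(=O)Nc4ccc(Cl)c(Cl)c4)c3)cc2-c2ccncc2)ccc1Cl`: 2130 nM
compound 2 `COc1cc(-c2nn(-c3cccc(NC(=O)Nc4ccc(Cl)c(C(F)(F)F)c4)c3)cc2-c2ccncc2)ccc1Cl`: 3090 nM

In a functional assay on OVCAR-5 cells (Homo sapiens) for inhibition, read by sulforhodamine B assay, with a stated time of 48 h (a higher number here means a weaker inhibitor of growth, a lower number a stronger inhibitor of growth), compound 1 gives 2130 nM, and compound 2 gives 3090 nM. Compound 2 holds the highest of the two numbers, although a 1.5-fold higher number from compound 1 to compound 2 (0.16 log units; within the scatter), so the two compounds cannot be ordered. Compound 3 `COc1cc(-c2nn(-c3cccc(NC(=O)c4ccccc4)c3)cc2-c2ccncc2)ccc1Cl` differs from compound 2 by phenyl in place of (4-chloro-3-(trifluoromethyl)phenyl)amino on a carbonyl carbon. Among the measured compounds shown here, the only measured step, from compound 1 to compound 2, swaps one group for another and stays within the scatter, so it does not bear on removing a whole amino-aryl portion. The expectation for compound 3 therefore rests on weak grounds and is given a wide range. Compound 3 is expected at 8000 nM, between 2000 nM and 30000 nM, an expected step of a 2.6-fold higher number from compound 2 to compound 3 (0.41 log units; beyond the scatter).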

Compound 3, concentration for 50% growth inhibition: 15000 nM
Compound 3: the middle estimate sits 1.9-fold (0.27 log units) below what was measured; the range from low to high includes it.
By their numbers in this assay, from the lowest: compounds 1 and 2 (each within the scatter of the next); then compound 3.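

Replacing the whole substituted phenylamino group on the carbonyl carbon with phenyl gives a 4.9-fold higher number from compound 2 to compound 3 (0.69 log units; beyond the scatter) and a 7.0-fold higher number from compound 1 to compound 3 (0.85 log units; beyond the scatter) in this assay and so shows that this position responds to change, which the earlier chloro-to-trifluoromethyl swap could not show. Compounds 1 and 2 are both stronger inhibitors of growth than compound 3. Nothing available explains this loss.

On these data alone, compound 3 loses the amino hydrogen and the ring's chloro and trifluoromethyl groups together, so their separate contributions remain unknown. As far as these compounds go, how an amine or a carboxylic acid on the phenyl ring would behave also remains open.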